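The source may report more compounds than this note shows. Statements on the series, on what has been measured and on what is new or still open speak of the compounds shown alone.

Measured compounds in the series:
- compound 1, `Clc1cncc(N2CCCNCCC2)c1`: 2 nM
- compound 2, `C=COc1cncc(N2CCNCC2)c1`: 191 nM
- compound 3, `C/C=C\Oc1cncc(N2CCCNCC2)c1`: 1.29 nM

In an assay on HEK293 cells for displacement of a labelled ligand from Neuronal acetylcholine receptor; alpha4/beta2 (Homo sapiens) (on this read-out lower numbers stand for stronger inhibition and higher numbers for weaker inhibition), compound 2 gives 191 nM and stands highest of the three numbers. Compound 1 gives 2 nM and compound 3 gives 1.29 nM. The gaps from compound 2 to each of the other two are well outside the usual scatter. Compounds 1 and 3 carry different groups on the shared core and a saturated amine ring of different size from that of compound 2, so the pair of values does not separate the two changes.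

Compound 4, `Clc1cncc(N2CCNCC2)c1`, is yet to be measured in this assay. It differs from compound 2 as follows: chloro in place of vinyloxy on an aromatic carbon. Compound 1 carries the same chloro group, compound 3 an alkenyloxy group, and their values lie close together, which suggests the exchange of the group on the aromatic carbon by itself has a limited effect; the saturated ring is unchanged between compound 2 and compound 4.

Compound 4 is therefore expected at 90 nM, in the range 25 nM to 320 nM. The expected step of a 2.1-fold lower number from compound 2 to compound 4 (0.33 log units; beyond the scatter) is a modest lowering, near the edge of the scatter.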

Compound 4, half-maximal inhibitory concentration: 309 nM
For compound 4 the middle estimate is 3.4-fold (0.54 log units) below the measured one, within the range that was stated.
By their numbers in this assay, from the lowest: compounds 3 and 1 (each within the scatter of the next); then compounds 2 and 4 (each within the scatter of the next).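

In this assay, among the compounds shown here, a 1.6-fold higher number from compound 2 to compound 4 (0.21 log units; within the scatter) is the first comparison that changes one place only, and on this saturated ring it does not separate vinyloxy, with 3 heavy atoms and 1 hydrogen-bond acceptor, from chloro, with 1 heavy atom and no hydrogen-bond acceptor. With chloro held constant, compound 4 gives 309 nM and compound 1, which differs in the saturated ring, gives 2 nM, so among these chloro compounds the large gap goes with the ring and not with the aromatic substituent. No available data explain why vinyloxy and chloro read alike here.

As far as these compounds go, it remains open whether an amine, a carboxylic acid or a longer alkoxy chain at this aromatic carbon would stay within the same range. Also open, from the compounds shown here alone, is whether the match between vinyloxy and chloro holds on the saturated ring of compound 1.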